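Trading a dimethoxyphenyl group for a 4-fluorophenyl group

The source may hold more compounds than are shown below. What is called first, only, known or untested is meant among the compounds shown, and "the series" means these compounds.

In a functional assay on MCF7 cells (Homo sapiens) for cytotoxicity, read by sulforhodamine B assay, with a stated time of 48 h (on this read-out higher numbers stand for weaker inhibition and lower numbers for stronger inhibition), compound 2 `COc1ccc(-c2cc(C(=O)/C=C/c3cccc(OC)c3OC)ccc2N)cc1OC` gives 10200 nM. That number lies within the scatter of each of the other two measured compounds: compound 1 `COc1cc(/C=C/C(=O)c2cccc(-c3cccc(F)c3)c2)ccc1O` gives 14200 nM and compound 3 `COc1ccc(/C=C/C(=O)c2ccc(N)c(-c3ccc(OC)c(OC)c3)c2)c(OC)c1` gives 6490 nM. Compound 4 `COc1cccc(/C=C/C(=O)c2ccc(N)c(-c3ccc(F)cc3)c2)c1OC` differs from compound 2 in one place: 4-fluorophenyl in place of 3,4-dimethoxyphenyl on an aromatic carbon. For the measured compounds named here, the only measured step, a 1.6-fold lower number from compound 2 to compound 3 (0.20 log units; within the scatter), lies at a different place in the molecule and stays within the scatter, so it bears only weakly on this change. Compound 1 also carries a fluorophenyl group, but it differs from compound 2 elsewhere too, and its value lies within the scatter of compound 2, with compound 1 at 14200 nM. No step beyond the scatter is therefore expected in this assay. The estimated step is small: a 1.1-fold higher number from compound 2 to compound 4 (0.03 log units; within the scatter). For compound 4 the expected value is 11000 nM, within an estimated range of 5000 nM to 24000 nM.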

Compound 4, half-maximal inhibitory concentration: 13300 nM
Compound 4: the middle estimate sits 1.2-fold (0.08 log units) below what was measured; low and high end bracket the measured number.
By their numbers in this assay, from the lowest: compounds 3, 2, 4 and 1 (each within the scatter of the next, the first and the last beyond it).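

In this assay, replacing 3,4-dimethoxyphenyl with 4-fluorophenyl on this aromatic carbon, ortho to an amino group, gives a 1.3-fold higher number from compound 2 to compound 4 (0.12 log units; within the scatter) and so stays within the scatter. For the compounds shown here, this is the first direct reading at this position: both methoxy groups can go and a fluorine can enter without a step beyond the scatter. No measurement shown explains this result.

As far as these compounds go, whether a carboxylic acid or a methyl group on this carbon would also stay within the scatter remains open. So does whether this change would read the same with the 2,4-dimethoxyphenyl group of compound 3.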